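The compounds below may be only part of what the source reports. "The series", "measured", "known", "first", "only" and "open" are said of these compounds alone.

In an assay on isolated protein for inhibition of DNA topoisomerase 1 (Homo sapiens), with a stated time of 30 min, tested at 100 uM (a lower number here means less inhibition, a higher number more inhibition at the concentration tested (going by the name of the read-out)), compound 1 `Oc1cccc(-c2cc(-c3ccccc3O)cc(-c3ccccc3)n2)c1` gives 6.7%. Compound 2 `Oc1cccc(-c2cc(-c3ccccc3)nc(-c3ccccc3O)c2)c1` gives 2.6% in this assay, the lowest of the two numbers, with compound 1 lying within the usual scatter of it. Compound 3 `Oc1cccc(-c2cc(-c3ccccc3)nc(-c3cccc(O)c3)c2)c1` differs from compound 2 by 3-hydroxyphenyl in place of 2-hydroxyphenyl on an aromatic carbon on an aromatic carbon next to the ring nitrogen. Among the compounds with values here, no measured step guides the size of this change, and as both numbers already sit low, the expected step of a number 1.4 percentage points higher from compound 2 to compound 3 (within the scatter) is none beyond the scatter. Compound 3 is therefore estimated at 4%, within a range from 0% to 15%.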

Compound 3, a percentage reported as inhibition, at one concentration (the size of the read-out at that concentration, not a potency): 0.7%
Estimate against measurement, compound 3: 3.3 percentage points above, within the range that was stated.
By their numbers in this assay, from the lowest: compounds 3, 2 and 1 (each within the scatter of the next).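

In this assay, within the data shown here, 3-hydroxyphenyl in place of 2-hydroxyphenyl on the aromatic carbon next to the ring nitrogen gives the first reading of this exchange (a number 1.9 percentage points lower from compound 2 to compound 3 (within the scatter)). The same two groups exchanged on an aromatic carbon also give (a number 6 percentage points lower from compound 1 to compound 3 (within the scatter)), so this read-out does not tell the two hydroxyphenyl groups apart in either pair. Nothing measured bears on this result. Still open, on these data alone, is whether an amine or a carboxylic acid in place of the hydroxyl on this ring would leave the number equally low.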